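The compounds below may be only part of what the source reports. "The series", "measured", "known", "first", "only" and "open" are said of these compounds alone.

Measured in a functional assay on MCF7 cells (Homo sapiens) for antiproliferative activity, read by sulforhodamine B assay, with a stated time of 3 days; a higher number here means a weaker inhibitor, a lower number a stronger inhibitor:
- compound 1 `c1nc(OCC2CCCCC2)c2nc[nH]c2n1` gives 32300 nM
- compound 2 `c1ccc(Oc2ncnc3c2ncn3C2COc3ccccc3CO2)cc1` gives 24700 nM

For the measured compounds named here, these two values lie within the scatter of each other, so compound 2 stands level with compound 1 on the numbers so far, and both sit in the same range. Compound 3 `c1ccc(Sc2ncnc3c2ncn3C2COc3ccccc3CO2)cc1` is the next to be read. It keeps everything in compound 2 except one group, with phenylsulfanyl in place of phenoxy on an aromatic carbon. Going by the values given here, no measured pair shows a change of this kind, so the expectation rests on the structural change alone. No shift beyond the scatter is expected in this assay, with at most a slight lean towards a lower number. The estimated step is a 1.5-fold lower number from compound 2 to compound 3 (0.19 log units; within the scatter) as an expectation only. The estimate for compound 3 is 16000 nM, with an expected range from 6000 nM to 40000 nM in this measurement.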

Compound 3, half-maximal inhibitory concentration: 7120 nM
The estimate for compound 3 lay 2.2-fold (0.35 log units) above the measured number; the measured number falls inside the stated range.
By their numbers in this assay, from the lowest: compound 3; then compounds 2 and 1 (each within the scatter of the next).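

In this assay, for the compounds shown here, the exchange of phenoxy for phenylsulfanyl on this aromatic carbon gives a 3.5-fold lower number from compound 2 to compound 3 (0.54 log units; beyond the scatter) and is the first step to lie beyond the scatter. The two groups match in everything counted, with the same number of heavy atoms and the same six-membered aromatic ring of carbon, and differ only in oxygen against sulfur, so this position responds to a single-atom exchange in the link to the phenyl ring. Nothing on hand accounts for the size or direction of this step.

Still open, on these data alone, is whether a nitrogen link, as in an anilino group, or a methylene link, as in a benzyl group, would follow phenylsulfanyl or phenoxy at this position. Also open, as far as these compounds go, is whether a chloro or methoxy group on the phenyl ring would move the number further.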